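One Carbon More on the Ring Amine: Compound 3

This account rests on a few compounds, and the source may have more. Where it says the series, first, only, none or still open, it means among the compounds named here.

Of the compounds shown here, two sharing one core have been measured in an assay on membranes from brain for displacement of a labelled ligand from Sigma non-opioid intracellular receptor 1 (Cavia porcellus), read by scintillation counting, with a stated time of 120 min; a lower number here means a stronger inhibitor, a higher number a weaker inhibitor. Compound 1 `CCCCN1CCN(CCC(=O)Nc2nc3c(C)cccc3s2)CC1` carries butyl on an amine nitrogen in a ring and gives 204 nM. Among the compounds with values here, compound 2 `Cc1cccc2sc(NC(=O)CCN3CCN(C4CCCCC4)CC3)nc12` carries cyclohexyl in that place and gives 24 nM; the step of an 8.5-fold lower number from compound 1 to compound 2 (0.93 log units; beyond the scatter) is the only measured step, and it leaves compound 2 with the lowest number of the two. Compound 3 `Cc1cccc2sc(NC(=O)CCN3CCN(CC4CCCCC4)CC3)nc12` is not yet measured; it differs from compound 2 by cyclohexylmethyl in place of cyclohexyl on an amine nitrogen in a ring. Within the data shown here, the one measured step bears only loosely on this change: it compares butyl with cyclohexyl, not cyclohexyl with cyclohexylmethyl, which again holds one six-membered non-aromatic ring of carbon only. A step in this assay beyond the scatter in either direction is therefore not expected. Compound 3 is estimated at 18 nM, between 6 nM and 60 nM. The expected step is a 1.3-fold lower number from compound 2 to compound 3 (0.12 log units; within the scatter), within the scatter.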

Compound 3, inhibition constant: 35 nM
Beside the measured number, compound 3's estimate is 1.9-fold (0.29 log units) below it; measured number inside the range.
By their numbers in this assay, from the lowest: compounds 2 and 3 (each within the scatter of the next); then compound 1.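

In this assay, moving to cyclohexylmethyl in place of cyclohexyl on the ring nitrogen gives a 1.5-fold higher number from compound 2 to compound 3 (0.16 log units; within the scatter) and so leaves the number within the scatter, which shows that this position accepts the cyclohexylmethyl group as well as the cyclohexyl group. Measured against the butyl of compound 1, the same group gives a 5.8-fold lower number from compound 1 to compound 3 (0.77 log units; beyond the scatter) and thus shows that both groups holding a six-membered non-aromatic ring of carbon only stand clear of butyl in this assay. Nothing at hand explains either step.

The compounds shown leave open whether benzyl or phenyl, which carry an aromatic ring, would behave like the cyclohexylmethyl and cyclohexyl groups at this nitrogen. They also leave open whether a longer chain to the ring, as in cyclohexylethyl, would hold the number in this assay where it stands.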